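The source may hold more compounds than are shown below. What is called first, only, known or untested is meant among the compounds shown, and "the series" means these compounds.

Working notes on a small series of thiocarbamate-linked anilides tested in an ADME assay on RAW264.7 cells (Mus musculus) for cytotoxicity, read by MTT assay, with a stated time of 48 h; a lower number here means a stronger inhibitor, a higher number a weaker inhibitor.

Compound 1 `COc1ccc(NC(=S)OCCNC(=O)C(C)(C)Oc2ccc(Cl)cc2)cc1` carries a methoxy-substituted aniline and a chlorophenoxy-isobutyramide tail. In this assay compound 1 returns a limit rather than a number, > 800000 nM. Compound 3 `Cc1ccc(NC(=S)OCCNC(=O)C(C)(C)Oc2ccc(Cl)cc2)cc1` shares the tail and differs from compound 1 only by methyl in place of methoxy on an aromatic carbon. In this assay compound 3 likewise gives a limit, > 800000 nM. The resulting step, a step that the two limits leave unreadable from compound 1 to compound 3, cannot be sized because of the limit of > 800000 nM in this assay, at which 3 of the 3 values shown sit.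

Compound 2 `COc1ccc(NC(=S)OCCNC(=O)c2cccnc2)cc1` keeps the methoxy-substituted aniline of compound 1 but carries a nicotinamide tail; how the two cores differ is not broken down here. In this assay compound 2 also sits at a limit, > 800000 nM.

Compound 4 `Cc1ccc(NC(=S)OCCNC(=O)c2cccnc2)cc1` is the not-yet-measured partner of compound 2, separated from it by methyl in place of methoxy on an aromatic carbon, the same change as that from compound 1 to compound 3. Since the pair compound 1 and compound 3 both rest at the limit, the change gives no readable signal on this core, and the expectation for compound 4 is carried mainly by the limit of compound 2 in this assay, > 800000 nM, with the step that the limit leaves unreadable from compound 2 to compound 4 expected to be small. For compound 4 the estimated value in this assay is therefore 1000000 nM, with an expected range from 500000 nM to 3000000 nM, most likely again reported only as a limit.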

Compound 4, half-maximal inhibitory concentration: > 800000 nM
Compound 4: no number, only a limit; the forecaster's own chance of this, stated with the estimate: 85%; the middle value lies beyond the limit too.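

No size can be read for the change from compound 2 to compound 4, because both compounds give only a limit and not a number: the limit of > 800000 nM in this assay, at which 4 of the 4 values shown sit.

The compounds shown leave open where any of them would fall in this assay as an actual number, and whether methyl in place of methoxy on an aromatic carbon alters the read-out on either core.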